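The source may report more compounds than this note shows. Statements on the series, on what has been measured and on what is new or still open speak of the compounds shown alone.

Measured compounds:
compound 1 `CC(C)Oc1cncc(C2=CC3CNCC(C2)C3)c1` — 0.26 nM
compound 2 `CC(C)Oc1cncc(C2=CC3CC(C2)CN(C)C3)c1` — 2.2 nM

Both numbers come from an in vitro assay on SH-EP1 cells for displacement of a labelled ligand from Neuronal acetylcholine receptor; alpha4/beta2 (Homo sapiens); on this read-out lower numbers stand for stronger inhibition and higher numbers for weaker inhibition. Going by the values given here, on the two values at hand, compound 1 stands lowest, and the one step available runs away from it: an 8.5-fold higher number from compound 1 to compound 2 (0.93 log units; beyond the scatter), which follows from a methyl in place of hydrogen on an amine nitrogen in a ring. Compound 3 `Clc1ccc(Oc2cncc(C3=CC4CNCC(C3)C4)c2)cc1` keeps that ring nitrogen unchanged and instead alters the other end of the molecule: 4-chlorophenyl in place of isopropyl on an oxygen on an aromatic ring. Among the compounds with values here, no measured pair shows this kind of swap, so the step to compound 2 describes a different part of the structure and gives no direct guide here. A larger group with an aromatic ring in place of a small branched chain is a substantial structural change, and the starting number of compound 1 is already very low, which leaves more room for the number to rise than to fall. The expectation for compound 3 is therefore a moderate rise in this assay, a 5.8-fold higher number from compound 1 to compound 3 (0.76 log units; beyond the scatter), with wide uncertainty. The estimated value for compound 3 is 1.5 nM, expected to lie between 0.2 nM and 15 nM.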

Compound 3, inhibition constant: 1.9 nM
The estimate for compound 3 lay 1.3-fold (0.10 log units) below the measured number; the range from low to high includes it.
By their numbers in this assay, from the lowest: compound 1; then compounds 3 and 2 (each within the scatter of the next).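

Going by these compounds alone, this is the first look at the group on the oxygen, since the earlier step concerned only the ring nitrogen. In this assay, 4-chlorophenyl in place of isopropyl gives a 7.3-fold higher number from compound 1 to compound 3 (0.86 log units; beyond the scatter), a modest loss that lies beyond the scatter, so isopropyl remains the better of the two groups tried at this place. Even so, with 7 heavy atoms and a six-membered aromatic ring where isopropyl had 3 heavy atoms and no ring, compound 3 still reads 1.9 nM, which shows that this place accepts a much larger group without the number leaving the low nanomolar range, though nothing available explains why the number moves as it does.

The compounds shown leave open whether the rise belongs to the aromatic ring itself or to its chlorine, a question that plain phenyl or 4-fluorophenyl on the same oxygen would help to separate. They also leave open how the number behaves with groups of other sizes at this place, such as a small methyl or a longer chain like n-butyl.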